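The source may hold more compounds than are shown below. What is called first, only, known or untested is meant among the compounds shown, and "the series" means these compounds.

Measured compounds:
- compound 1, `COc1cc(-c2nnc3n2NC(c2ccco2)C(C(=O)c2ccc(F)c(F)c2)S3)cc(OC)c1OC`, 93700 nM
- compound 2, `COc1cc(-c2nnc3n2NC(c2ccco2)C(C(=O)c2ccco2)S3)cc(OC)c1OC`, 68700 nM
- compound 3, `COc1cc(-c2nnc3n2NC(c2ccco2)C(C(=O)c2ccccc2F)S3)cc(OC)c1OC`, 78700 nM

All three were tested in a functional assay on A549 cells (Homo sapiens) for cytotoxicity, read by MTT assay, with a stated time of 48 h; on this read-out higher numbers stand for weaker inhibition and lower numbers for stronger inhibition. Compound 1 gives the highest of the three numbers, but the differences are small: the step of a 1.4-fold lower number from compound 1 to compound 2 (0.13 log units; within the scatter) and the step of a 1.2-fold lower number from compound 1 to compound 3 (0.08 log units; within the scatter) both lie within the scatter, as does the step of a 1.1-fold higher number from compound 2 to compound 3 (0.06 log units; within the scatter). So the three measured compounds cannot be told apart on these numbers.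

Compound 4, `COc1cc(-c2nnc3n2NC(c2ccco2)C(C(=O)c2ccc(-c4ccccc4)cc2)S3)cc(OC)c1OC`, has not yet been measured. It differs from compound 1 by 4-phenylphenyl in place of 3,4-difluorophenyl on a carbonyl carbon. The two measured steps from compound 1 both replace the same group on the same carbonyl carbon, and neither moved the number beyond the scatter. The group entering in compound 4 is larger than anything tried so far, so those steps bear on it only loosely. On that basis compound 4 is expected to give a number near that of compound 1, with the estimated step being a 1.2-fold lower number from compound 1 to compound 4 (0.07 log units; within the scatter). The expected value for compound 4 in this assay is therefore 80000 nM, with a range from 30000 nM to 200000 nM.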

Compound 4, half-maximal inhibitory concentration: > 100000 nM
Compound 4 ended at the assay's limit; the forecaster's own chance of this, stated with the estimate: 20%; at least 1.2-fold (0.09 log units) between middle value and limit.
By their numbers in this assay, from the lowest: compounds 2, 3 and 1 (each within the scatter of the next). At a limit, above all of these: compound 4.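

In this assay, compound 4, with the two-ring 4-phenylphenyl on this carbonyl carbon, sits at a limit of the assay, > 100000 nM, and this is not a true number. Its steps can be read only as floors: an at least 1.0-fold higher number from compound 1 to compound 4 (0.02 log units; that floor lies within the scatter), an at least 1.2-fold higher number from compound 3 to compound 4 (0.10 log units; that floor lies within the scatter) and an at least 1.4-fold higher number from compound 2 to compound 4 (0.16 log units; that floor lies within the scatter). So this larger group brought no stronger inhibition at this position, but whether it truly weakened inhibition cannot be said, because each step ends at a limit and its floor stays within the scatter: the limit of > 100000 nM in this assay, at which 1 of the 4 values shown sits.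

No group shown here moves the number beyond the scatter, and how far compound 4 lies past its limit remains open. From the compounds shown here alone, whether an amine such as morpholine or a carboxylic acid on this carbonyl carbon would shift the number also remains open.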